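The source may report more compounds than this note shows. Statements on the series, on what has been measured and on what is new or still open speak of the compounds shown alone.

In a functional assay on OVCAR-3 cells (Homo sapiens) for cytotoxicity, read by sulforhodamine B assay (on this read-out higher numbers stand for lower toxicity in this test and lower numbers for higher toxicity in this test), compound 1 `CC1=CC[C@@H]([C@@](C)(O)CCCC(C)(C)NC(=S)N/N=C\c2ccc(O)cc2)CC1` gives 54400 nM. Compound 2 `CC1=CC[C@@H]([C@@](C)(O)CCCC(C)(C)NC(=S)N/N=C\c2ccc([N+](=O)[O-])cc2)CC1` stands at > 100000 nM, which is a limit of the assay and not a number. Next comes compound 3 `CC1=CC[C@@H]([C@@](C)(O)CCCC(C)(C)NC(=S)N/N=C\c2cccc(Cl)c2)CC1`, with the change (3-chlorophenyl in place of 4-nitrophenyl on a carbon with a double bond to nitrogen). For the measured compounds named here, the one measured step that bears on this, nitro in place of hydroxy on an aromatic carbon, is an at least 1.8-fold higher number from compound 1 to compound 2 (0.26 log units; that floor lies within the scatter). It gives only a floor and does not cover 3-chlorophenyl, so its size carries over weakly. Going by the values given here, the expectation therefore leans on compound 1 at 54400 nM, the only true number. A modest move towards lower numbers in this assay is expected, perhaps none beyond the scatter, and the estimated change is an at least 1.6-fold lower number from compound 2 to compound 3 (0.22 log units; that floor lies within the scatter). For compound 3 the estimated value is 60000 nM, with an expected range from 20000 nM to 100000 nM.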

Compound 3, concentration lethal to 50% of the cells: 48000 nM
For compound 3 the middle estimate is 1.3-fold (0.10 log units) above the measured one; the range from low to high includes it.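

In this assay, for the compounds shown here, 3-chlorophenyl in place of 4-nitrophenyl on a carbon with a double bond to nitrogen gives an at least 2.0-fold lower number from compound 2 to compound 3 (0.31 log units; beyond the scatter), the first step to clear the scatter, so the read-out does respond to a change at this position. Going by these compounds, compound 2 stands at a limit of the assay and not a number, so the full size of that step stays unknown: the limit of > 100000 nM in this assay, at which 1 of the 3 values shown sits. The change from the hydroxy-bearing ring gives a 1.1-fold lower number from compound 1 to compound 3 (0.05 log units; within the scatter), so compound 1 and compound 3 cannot be told apart here.

On these data alone, whether a plain phenyl ring would read with compound 1 and compound 3 or with compound 2 remains open. So does the effect of an amine or a carboxylic acid on the ring at this position.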